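Triazole thioether series: pyridinyl piperazine with chlorophenyl

The compounds below may be only part of what the source reports. "The series", "measured", "known", "first", "only" and "open" are said of these compounds alone.

Measured so far in a functional assay on THP-1 cells (Homo sapiens) for cytotoxicity, read by MTT assay, with a stated time of 24 h; a lower number here means a stronger inhibitor, a higher number a weaker inhibitor:
compound 1, `CCN1CCN(CCCSc2nnc(-c3ccc(C)cc3)[nH]2)CC1`: > 300000 nM, a limit of the assay.
compound 2, `Cc1cccc(-c2nnc(SCCCN3CCN(c4ccccn4)CC3)[nH]2)c1`: > 300000 nM, a limit of the assay.
compound 3, `CCN1CCN(CCCSc2nnc(-c3ccccc3Cl)[nH]2)CC1`: > 300000 nM, a limit of the assay.

Compound 3 therefore stands nowhere that can be ranked: every value in this assay is a limit, and the limit of > 300000 nM in this assay, at which 3 of the 3 values shown sit, holds for all three. For the measured compounds named here, the one single-point step among them, a step that the two limits leave unreadable from compound 1 to compound 3, cannot be read for the same reason.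

The next compound, compound 4, `Clc1ccccc1-c1nnc(SCCCN2CCN(c3ccccn3)CC2)[nH]1`, differs from compound 3 by pyridin-2-yl in place of ethyl on an amine nitrogen in a ring. Going by the values given here, the closest measured guide is compound 2, which carries the same pyridin-2-yl group on its piperazine and sits at the limit as well; no measured step that bears on this change gives a readable size, so no direction beyond the scatter can be claimed for it.

Compound 4 is accordingly expected to remain at or beyond the same limit, with an estimated value of 400000 nM (range 150000 nM to 1500000 nM). The expected step is a step that the limit leaves unreadable from compound 3 to compound 4, that is, none beyond the scatter.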

Compound 4, half-maximal inhibitory concentration: > 300000 nM
Compound 4 ended at the assay's limit; the forecaster's own chance of this, stated with the estimate: 85%; the middle value is on the limit's open side.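

Compound 4 stands at a limit in this assay, as compound 2 and compound 3 do, so neither of its steps from those two compounds can be read: the limit of > 300000 nM in this assay, at which 4 of the 4 values shown sit.

The compounds shown leave open whether any change to the shared core gives a value inside that limit in this assay.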